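A Ring Substituent Swap and Its Expected Effect

The compounds below may be only part of what the source reports. "The series", "measured", "known", "first", "only" and "open" are said of these compounds alone.

For the measured compounds named here, compound 1 `Nc1scc(CN2CCN(c3ccc([N+](=O)[O-])cc3)CC2)c1C(=O)c1ccc(Cl)cc1` is one of two compounds measured in a functional assay on CHO cells with adenosine receptor A1 (Homo sapiens) as the target, read by cAMP accumulation and immunoassay, with a stated time of 6 min, tested at 10 uM (a higher number here means a weaker effect of the compound at the concentration tested, a lower number a stronger effect), where compound 1 gives -17%. Compound 2 `Nc1scc(CN2CCN(c3c(F)cccc3F)CC2)c1C(=O)c1cccc(C(F)(F)F)c1` gives 4% in this assay, a number beyond the scatter above compound 1, so compound 1 stands lowest of the two. Compound 3 `Nc1scc(CN2CCN(c3ccccc3F)CC2)c1C(=O)c1ccc(Cl)cc1` has not been measured; it differs from compound 1 in one place: 2-fluorophenyl in place of 4-nitrophenyl on an amine nitrogen in a ring. Going by the values given here, no measured pair shows this change alone, so its effect is not known from these data. The step from compound 1 to compound 3 is expected to be modest, a number 15 percentage points higher from compound 1 to compound 3 (beyond the scatter), toward a weaker effect. Compound 3 is estimated at -2%, between -25% and 20%.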

Compound 3, a percentage reported as activity, at one concentration (the size of the read-out at that concentration, not a potency): -15%
Compound 3: middle estimate off by 13 percentage points, on the high side; low and high end bracket the measured number.
By their numbers in this assay, from the lowest: compounds 1 and 3 (each within the scatter of the next); then compound 2.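

For the compounds shown here, putting 2-fluorophenyl in place of 4-nitrophenyl on this amine nitrogen in a ring gives a number 2 percentage points higher from compound 1 to compound 3 (within the scatter) in this assay and is the first view of this change alone. At this concentration, the read-out does not separate the two groups, even though 4-nitrophenyl carries hydrogen-bond acceptors and 2-fluorophenyl carries none. Nothing available explains this outcome. As far as these compounds go, whether a plain phenyl, a benzyl or a ring bearing a carboxylic acid would read the same here stays open. So does the behaviour of these compounds at other concentrations.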